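Alkylamino variation on the chloro-triazine core, S-configured series

The compounds below may be only part of what the source reports. "The series", "measured", "known", "first", "only" and "open" are said of these compounds alone.

Compound 1 `CNc1nc(Cl)nc(N[C@@H](C)c2ccccc2)n1` is assessed in an ADME assay on the whole organism for inhibition, with Echinochloa crus-galli var. formosensis as the target, with a stated time of 4 days; a lower number here means a stronger inhibitor, a higher number a weaker inhibitor. Compound 1 gives 26900 nM, the second highest of the three numbers. Compound 2 `CCN(c1nc(Cl)nc(N[C@H](C)c2ccccc2)n1)C(C)C` gives 52500 nM and compound 3 `CNc1nc(Cl)nc(N[C@H](C)c2ccccc2)n1` gives 562 nM. Of these, compound 1 and compound 2 lie within the scatter of each other, while a 48-fold lower number from compound 1 to compound 3 (1.68 log units; beyond the scatter) is large, and rests on (the fact that compounds 1 and 3 differ only in the configuration as drawn). The step of a 93-fold lower number from compound 2 to compound 3 (1.97 log units; beyond the scatter) shows that in the other configuration a methylamino group goes with a far lower number than a bulkier dialkylamino group on the same aromatic carbon.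

Compound 4 `CCN(CC)c1nc(Cl)nc(N[C@@H](C)c2ccccc2)n1` is the next member, not yet measured. It differs from compound 1 as follows: diethylamino in place of methylamino on an aromatic carbon. The step from compound 2 to compound 3 is the one that bears on this change, read in reverse: moving from methylamino to a larger dialkylamino gave a large rise in the number. A rise beyond the scatter is therefore expected here too, though diethylamino is not the same group as ethyl(isopropyl)amino. Compound 4 is estimated at 150000 nM, in the range 40000 nM to 600000 nM, corresponding to an expected step of a 5.6-fold higher number from compound 1 to compound 4 (0.75 log units; beyond the scatter).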

Compound 4, half-maximal inhibitory concentration: 257 nM
Compound 4: middle estimate off by 580-fold (2.77 log units), on the high side, and the stated range ends above it.
By their numbers in this assay, from the lowest: compound 4; then compound 3; then compounds 1 and 2 (each within the scatter of the next).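

With the configuration held as drawn in compound 1, diethylamino in place of methylamino on this aromatic carbon gives a 100-fold lower number from compound 1 to compound 4 (2.02 log units; beyond the scatter) in this assay, so a larger dialkylamino group here does not always go with a higher number. The other configuration runs the opposite way, with methylamino holding the lower number: a 93-fold lower number from compound 2 to compound 3 (1.97 log units; beyond the scatter). These two pairs differ in both configuration and dialkylamino group, and nothing measured here gives a reason for the direction or size of the new step.

Open, as far as these compounds go, is whether the reversal follows the configuration or the dialkylamino group, which diethylamino in the configuration of compound 3 would help to separate. Also open, from the compounds shown here alone, is how this position responds to ethylamino or to a cyclic amine such as pyrrolidine.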